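A few compounds are considered here, and "the series" means these few. Any claim that something is new, unique, unknown or untested is made for them only; others in the source may bear on it.

Within the data shown here, compound 1 `O=C(CN(c1ncnc2c1ncn2C1CCCCO1)C1CC1)N[C@@H](CCC(=O)OCc1ccccc1)C(=O)OCc1ccccc1` is one of three compounds measured in a functional assay on the whole organism (Tail, strain ICR) with Mus musculus as the target, in the tail flick test, with a stated time of 60 min, at a dose of 25 umol/kg by the oral route; a higher number here means a stronger effect of the compound at the dose given, a lower number a weaker effect. In this assay compound 1 gives 34.7%, the lowest of the three numbers. Compound 3 `CC[C@H](C)[C@H](NC(=O)CN(c1nc(Cl)nc2[nH]cnc12)C1CC1)C(=O)OCc1ccccc1` gives 40.6%, which lies within the scatter of compound 1, while compound 2 `O=C(CN(c1nc(Cl)nc2[nH]cnc12)C1CC1)N[C@@H](CCC(=O)OCc1ccccc1)C(=O)OCc1ccccc1` gives 53.7%, beyond the scatter above compound 1. Compound 4 `CC(C)(C)OC(=O)NCCCC[C@H](NC(=O)CN(c1ncnc2c1ncn2C1CCCCO1)C1CC1)C(=O)OCc1ccccc1` differs from compound 1 only in the side chain of the amino acid ester: 2-((tert-butoxycarbonyl)amino)ethyl in place of benzyloxycarbonyl on a saturated chain carbon, three bonds along the chain from an amide-type nitrogen and a carbonyl carbon. Among the measured compounds shown here, one measured step touches this chain, on a different core: a number 13.1 percentage points lower from compound 2 to compound 3 (beyond the scatter). For the measured compounds named here, that step removes the 2-(benzyloxycarbonyl)ethyl chain for a sec-butyl group, a smaller and different change from the one here, so it bears only loosely on the present exchange, and no measured pair trades a benzyloxycarbonyl for a 2-((tert-butoxycarbonyl)amino)ethyl. The expected step is therefore a number 0.3 percentage points higher from compound 1 to compound 4 (within the scatter), not beyond the scatter in either direction. The estimate for compound 4 in this assay is 35%, with a range from 20% to 50%.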

Compound 4, a percentage reported as activity, at one dose (the size of the read-out at that dose, not a potency): 32.7%
For compound 4 the middle estimate is 2.3 percentage points above the measured one, within the range that was stated.
By their numbers in this assay, from the lowest: compounds 4, 1 and 3 (each within the scatter of the next); then compound 2.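

In this assay, among these compounds, the exchange at this position reads as a number 2 percentage points lower from compound 1 to compound 4 (within the scatter) and is the first step measured on the core of compound 1. The chain end with a six-membered aromatic ring of carbon only thus gives way to a ringless chain end carrying a hydrogen-bond donor, and the read-out at this dose stays within the scatter, so for this pair the ring in the chain is not required to keep the number where it stands. Nothing available explains this outcome.

As far as these compounds go, it remains open whether a free amine or a carboxylic acid at the end of this chain would hold the number in the same place. From the compounds shown here alone, it is also open whether the same exchange on the core of compound 2 would leave the read-out just as unmoved.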